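The source may report more compounds than this note shows. Statements on the series, on what has been measured and on what is new or still open speak of the compounds shown alone.

Compound 3 `COc1ccc(CSc2nnc([C@@H](C)c3ccc4cc(OC)ccc4c3)n2-c2ccc(F)cc2)cc1` has been tested in a functional assay on DU-145 cells (Homo sapiens) for cytotoxicity, read by MTT assay; a lower number here means a stronger inhibitor, a higher number a weaker inhibitor. In this assay compound 3 gives only a limit, <= 400000 nM, not a number. That reading is one of those at the limit of <= 400000 nM in this assay, at which 1 of the 3 values shown sits. Compound 4 `COc1ccc2cc([C@H](C)c3nnc(SCc4c(C)cc(C)cc4C)n3-c3ccc(F)cc3)ccc2c1` differs from compound 3 in one place: 2,4,6-trimethylphenyl in place of 4-methoxyphenyl on a saturated chain carbon bound to a sulfur. Going by the values given here, no measured pair shows this exact change. The nearest guide is the pair of compound 1 `COc1ccc2cc([C@H](C)c3nnc(SCc4ccccc4)n3-c3ccc(Cl)cc3)ccc2c1`, which gives 35800 nM in this assay, and compound 2 `COc1ccc2cc([C@H](C)c3nnc(SCc4ccc(C)cc4)n3-c3ccc(Cl)cc3)ccc2c1`, which gives 18800 nM; their step, a 1.9-fold lower number from compound 1 to compound 2 (0.28 log units; within the scatter), lies within the scatter. Compound 4 is therefore expected to sit near the numbers of compound 1 and compound 2, estimated at 30000 nM with a range from 8000 nM to 150000 nM. This estimate means an expected step that the limit leaves unreadable from compound 3 to compound 4.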

Compound 4, half-maximal inhibitory concentration: 10200 nM
Compound 4: middle estimate off by 2.9-fold (0.47 log units), on the high side; low and high end bracket the measured number.
By their numbers in this assay, from the lowest: compounds 4, 2 and 1 (each within the scatter of the next, the first and the last beyond it).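

Compound 3 gives only a limit, not a number, so the step from compound 3 to compound 4 cannot be read: the limit of <= 400000 nM in this assay, at which 1 of the 4 values shown sits.

The compounds shown leave open how far 2,4,6-trimethylphenyl in place of 4-methoxyphenyl moves the number on its own.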